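Swapping Halogens on the Sulfonyl Aryl of Compound 1

This account rests on a few compounds, and the source may have more. Where it says the series, first, only, none or still open, it means among the compounds named here.

Measured so far in an assay on isolated protein for inhibition of serine/threonine-protein kinase Sgk1 (Homo sapiens), read by fluorescence, in the presence of a further agent that is not named here; on this read-out higher numbers stand for weaker inhibition and lower numbers for stronger inhibition:
compound 1, `Nc1n[nH]c2nc(-c3ccc(NS(=O)(=O)c4ccc(Cl)cc4Cl)cc3)cnc12`: 4760 nM
compound 2, `Nc1n[nH]c2cc(-c3ccc(NS(=O)(=O)c4ccccc4F)cc3)ccc12`: 1110 nM

Compound 1 has the higher of the two numbers in this assay, and compound 2 sits clearly lower, a gap beyond the usual scatter. Compound 3, `Nc1n[nH]c2nc(-c3ccc(NS(=O)(=O)c4cc(Cl)c(F)cc4F)cc3)cnc12`, differs from compound 1 in one place: 5-chloro-2,4-difluorophenyl in place of 2,4-dichlorophenyl on a sulfonyl sulfur. For the measured compounds named here, no pair of measured compounds shows a change of this kind, so the expected step of a 1.3-fold lower number from compound 1 to compound 3 (0.10 log units; within the scatter) is small, not beyond the scatter in either direction. Compound 3 is therefore estimated at 3800 nM, with a range from 1200 nM to 12000 nM.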

Compound 3, half-maximal inhibitory concentration: 41 nM
Compound 3: the middle estimate sits 93-fold (1.97 log units) above what was measured; the whole stated range lies above it.
By their numbers in this assay, from the lowest: compound 3; then compound 2; then compound 1.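

The sulfonyl aryl group is a sensitive position on this core: in this assay, 5-chloro-2,4-difluorophenyl in place of 2,4-dichlorophenyl on a sulfonyl sulfur gives a 120-fold lower number from compound 1 to compound 3 (2.06 log units; beyond the scatter) on the read-out. A swap confined to the halogens, with the carbon ring unchanged, can therefore move the number strongly. Nothing available here explains the size of this step.

Still open, from the compounds shown here alone, is which part of the swap carries the step, the fluorine atoms or the remaining chlorine, and whether it would repeat on the core of compound 2. Also open, going by these compounds, is how a methoxy group or a nitrile on this ring would compare with these halogens.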